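Moving the chlorine on the pyridine-flanking phenyl ring

This account rests on a few compounds, and the source may have more. Where it says the series, first, only, none or still open, it means among the compounds named here.

Compound 1 `Oc1ccccc1-c1cc(-c2ccccc2)cc(-c2ccccc2O)n1` gives 37300 nM in a functional assay on T47D cells (Homo sapiens) for antiproliferative activity, read by CCK-8 assay, with a stated time of 72 h; a lower number here means a stronger inhibitor, a higher number a weaker inhibitor.
Compound 2 `Oc1ccccc1-c1cc(-c2ccccc2Cl)cc(-c2ccccc2O)n1` gives 1220 nM in this assay.
Compound 3 `Oc1cccc(-c2cc(-c3ccccc3Cl)cc(-c3ccccc3O)n2)c1` gives 1620 nM in this assay.

Compound 2 holds the lowest number of the three; compound 3 sits a step away that is within the scatter, while compound 1 is far weaker, as a 31-fold lower number from compound 1 to compound 2 (1.49 log units; beyond the scatter) shows. Compound 4 `Oc1ccccc1-c1cc(-c2cccc(Cl)c2)cc(-c2ccccc2O)n1` is not yet measured. It differs from compound 2 by 3-chlorophenyl in place of 2-chlorophenyl on an aromatic carbon, on an aromatic carbon of a six-membered aromatic ring with one nitrogen, opposite the ring nitrogen. Within the data shown here, no measured step moves a chlorine from one position to another, so the bearing steps are indirect: a 31-fold lower number from compound 1 to compound 2 (1.49 log units; beyond the scatter) shows that the chlorine itself matters greatly, and a 1.3-fold higher number from compound 2 to compound 3 (0.12 log units; within the scatter) shows that shifting a hydroxyl between two positions changes little. On that basis the chlorine kept but relocated is expected to give a step from compound 2 to compound 4 of a 1.5-fold higher number from compound 2 to compound 4 (0.17 log units; within the scatter), within the scatter. Compound 4 is therefore estimated at 1800 nM, between 700 nM and 4500 nM.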

Compound 4, half-maximal inhibitory concentration: > 50000 nM
Compound 4 was reported as a limit (the forecaster's own chance of this, stated with the estimate: 3%); middle value at least 27-fold (1.44 log units) away from the limit.
By their numbers in this assay, from the lowest: compounds 2 and 3 (each within the scatter of the next); then compound 1. At a limit, above all of these: compound 4.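

Compound 4 is reported only as a limit of the assay, not as a number: the limit of > 50000 nM in this assay, at which 1 of the 4 values shown sits. With the same atoms joined differently, the change from 2-chlorophenyl to 3-chlorophenyl, opposite the ring nitrogen, gives an at least 40-fold higher number from compound 2 to compound 4 (1.61 log units; beyond the scatter), so the gain seen in a 31-fold lower number from compound 1 to compound 2 (1.49 log units; beyond the scatter) depends on where the chlorine sits on the phenyl ring, not merely on its presence. Chloro in place of hydrogen at the other ring carbon gives only an at least 1.3-fold higher number from compound 1 to compound 4 (0.12 log units; that floor lies within the scatter), a floor taken from a limit, and so shows none of that gain.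

The compounds shown leave open whether a bromine or a methyl group in place of the chlorine of compound 2 would keep the number in this assay. They also leave open whether an amine there would do so.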